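A Methoxy Substituent on the Aromatic Ring of Compound 2

The compounds below may be only part of what the source reports. "The series", "measured", "known", "first", "only" and "open" are said of these compounds alone.

Measured so far:
compound 1 `COC(=O)[C@@]1(C)CCC=C2[C@@H]1CC[C@@H](C)[C@]2(C)Cc1c[nH]c2ccc(Br)cc12`, 16000 nM
compound 2 `COC(=O)[C@@]1(C)CC[C@@H]2C3=C1CC[C@@H](C)[C@]3(C)Cc1c2[nH]c2ccccc12`, 3400 nM

In a functional assay on T47D cells (Homo sapiens) for inhibition, read by sulforhodamine B assay, with a stated time of 48 h (on this read-out lower numbers stand for stronger inhibition of growth and higher numbers for weaker inhibition of growth), compound 2 gives 3400 nM, the lowest of the two numbers shown. Compound 1 gives 16000 nM, a higher number that lies beyond the usual scatter. For the measured compounds named here, these two compounds differ in more than one place, so their values show only that compound 2 inhibits growth more strongly than compound 1.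

Compound 3 `COC(=O)[C@@]1(C)CC[C@@H]2C3=C1CC[C@@H](C)[C@]3(C)Cc1c2[nH]c2ccc(OC)cc12` keeps the core of compound 2 and differs from it in a single place: methoxy in place of hydrogen on an aromatic carbon. Going by the values given here, no measured pair shows this change, so its effect is not known from the data at hand. Compound 3 is expected to stay close to compound 2, with an estimated step of a 1.2-fold higher number from compound 2 to compound 3 (0.07 log units; within the scatter) that may fall within the scatter in either direction. In this assay the estimate for compound 3 is 4000 nM, with a range from 1300 nM to 12000 nM.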

Compound 3, concentration for 50% growth inhibition: 6500 nM
The estimate for compound 3 lay 1.6-fold (0.21 log units) below the measured number; low and high end bracket the measured number.
By their numbers in this assay, from the lowest: compounds 2 and 3 (each within the scatter of the next); then compound 1.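

In this assay the read-out shows a 1.9-fold higher number from compound 2 to compound 3 (0.28 log units; within the scatter) for methoxy in place of hydrogen on an aromatic carbon. For the compounds shown here, this is the first measured change at this place on the six-membered aromatic ring, and it shows that the position carries methoxy, with its 2 heavy atoms and 1 hydrogen-bond acceptor, without a difference that can be told from the scatter. No measurement at hand bears on why the two compounds read alike.

As far as these compounds go, a single substituent at this carbon gives no trend, so it remains open whether the position would tolerate a different group on the same core, such as an amine or a carboxylic acid, as it does methoxy. From the compounds shown here alone, it also remains open whether a longer chain on the oxygen, such as ethoxy, would stay within the scatter of compound 2.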